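Working notes: adding a methoxy to compound 2

The compounds below may be only part of what the source reports. "The series", "measured", "known", "first", "only" and "open" are said of these compounds alone.

Measured so far:
- compound 1 `COc1ccc(/C=C2\CCC/C(=C\c3cccc(OC)c3OC)C2=O)cc1`: 18600 nM
- compound 2 `COc1ccc(/C=C2\CCC/C(=C\c3cccc(OC)c3OC)C2=O)cc1OC`: 6500 nM

In a functional assay on MCF7 cells (Homo sapiens) for cytotoxicity, read by MTT assay, with a stated time of 72 h (on this read-out higher numbers stand for weaker inhibition and lower numbers for stronger inhibition), compound 2 holds the lower of the two numbers, 6500 nM. The next compound to be measured is compound 3 `COc1cccc(/C=C2\CCC/C(=C\c3cc(OC)c(OC)c(OC)c3)C2=O)c1OC`. It differs from compound 2 in one place: methoxy in place of hydrogen on an aromatic carbon. A methoxy replaces hydrogen on an aromatic carbon, ortho to a methoxy group, meta to a large group and meta to a second methoxy group.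

Among the compounds with values here, one measured step bears on this, the same kind of change on the same ring: a 2.9-fold lower number from compound 1 to compound 2 (0.46 log units; beyond the scatter). That single step is modest and beyond the scatter, but it cannot establish a trend. A second modest drop in this assay is therefore expected, with little confidence in its size. The expected step is a 1.6-fold lower number from compound 2 to compound 3 (0.21 log units; within the scatter). For compound 3 the estimated value is 4000 nM, with an expected range of 1300 nM to 13000 nM.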

Compound 3, half-maximal inhibitory concentration: 1400 nM
Beside the measured number, compound 3's estimate is 2.9-fold (0.46 log units) above it; the range from low to high includes it.
By their numbers in this assay, from the lowest: compound 3; then compound 2; then compound 1.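

In this assay, a second methoxy on the same ring, at the carbon ortho to a methoxy group, meta to a large group and meta to a second methoxy group, gives a 4.6-fold lower number from compound 2 to compound 3 (0.67 log units; beyond the scatter). Within the data shown here, the single earlier step could not show whether the change would repeat; now two hydrogen-to-methoxy steps on this ring run in the same direction, and none of compounds 1 to 3 goes against that. No supporting measurement bears on why this step occurs.

The compounds shown leave open whether this position needs a methoxy specifically, or whether a hydroxyl, an amine or a longer chain such as ethoxy would give a similar step. They also leave open whether the same change would hold on the other aromatic ring of the shared core.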